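The source may report more compounds than this note shows. Statements on the series, on what has been measured and on what is new or still open speak of the compounds shown alone.

Three compounds have been measured in a functional assay on the whole organism (strain albino) for inhibition, with Rattus norvegicus as the target, read by paw edema, with stated times of 1 h and 4 h, at a dose of 200 mg/kg by the oral route; on this read-out lower numbers stand for less inhibition and higher numbers for more inhibition at the one dose given (going by the name of the read-out):
compound 1 `O=c1oc2ccccc2cc1C1=NN(c2ccccc2)[C@@H](/C=C/c2ccccc2)C1` gives 42.5%;
compound 2 `COc1cccc([C@H]2CC(c3cc4ccccc4oc3=O)=NN2c2ccccc2)c1` gives 61.5%;
compound 3 `O=c1oc2ccccc2cc1C1=NN(c2ccccc2)[C@@H](c2ccc(F)cc2)C1` gives 66.7%.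

Compound 3 holds the highest of the three numbers, yet its value and that of compound 2 lie within the scatter of each other, so no order between them can be read; only compound 1 stands apart, by a number 24.2 percentage points higher from compound 1 to compound 3 (beyond the scatter). Compound 4 `O=c1oc2ccccc2cc1C1=NN(c2ccccc2)[C@@H](c2ccccc2[N+](=O)[O-])C1` differs from compound 3 in one place: 2-nitrophenyl in place of 4-fluorophenyl on a saturated ring carbon. Within the data shown here, the one measured step that swaps one aryl group for another on this saturated ring carbon, a number 5.2 percentage points higher from compound 2 to compound 3 (within the scatter), stayed within the scatter, whereas the larger steps of a number 19 percentage points higher from compound 1 to compound 2 (beyond the scatter) and a number 24.2 percentage points higher from compound 1 to compound 3 (beyond the scatter) both replaced 2-phenylethenyl. Compound 4 is therefore expected to show no shift beyond the scatter, a number 4.7 percentage points lower from compound 3 to compound 4 (within the scatter). Compound 4 is estimated at 62%, with a range from 48% to 76%.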

Compound 4, a percentage reported as inhibition, in the whole organism at one dose (the size of the read-out at that dose, not a potency): 26.6%
Beside the measured number, compound 4's estimate is 35.4 percentage points above it; the whole stated range lies above it.
By their numbers in this assay, from the lowest: compound 4; then compound 1; then compounds 2 and 3 (each within the scatter of the next).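

On this saturated ring carbon, the choice of aryl group can matter a great deal in this assay: the change to 2-nitrophenyl gives a number 40.1 percentage points lower from compound 3 to compound 4 (beyond the scatter) and a number 34.9 percentage points lower from compound 2 to compound 4 (beyond the scatter), unlike the earlier aryl swap, which stayed within the scatter. With a number 15.9 percentage points lower from compound 1 to compound 4 (beyond the scatter), replacing 2-phenylethenyl with an aryl group no longer always raises the number, as it did for compounds 2 and 3. Nothing available accounts for this drop. The compounds shown leave open whether it follows the nitro group itself or its place on the phenyl ring, and how a 2-aminophenyl or 4-nitrophenyl group would read here.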